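The compounds below may be only part of what the source reports. "The series", "measured", "known", "first", "only" and "open" are said of these compounds alone.

Compound 1 `COC(=O)c1c(-c2ccc(Br)cc2)oc2ccccc2c1=O`: > 25 ug/mL
Compound 2 `COC(=O)c1c(-c2ccc([N+](=O)[O-])cc2)oc2cc(OC)ccc2c1=O`: > 25 ug/mL

Both entries come from a functional assay on A549 cells (Homo sapiens) for cytotoxicity, read by MTT assay, with a stated time of 6 days; on this read-out higher numbers stand for an effect only at larger amounts of compound and lower numbers for an effect already at smaller amounts. Compound 1 stands at > 25 ug/mL, which is a limit of the assay and not a number. Compound 2 stands at > 25 ug/mL, which is also a limit. For compound 1 and compound 2, the record so far is the limit of > 25 ug/mL in this assay, at which 2 of the 2 values shown sit, so compound 1 offers no exact starting value.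

Compound 3 `COC(=O)c1c(-c2ccc(N)cc2)oc2ccccc2c1=O` keeps the core of compound 1 but has amino in place of bromo on an aromatic carbon, para to a large group: amino in place of bromo on an aromatic carbon. For the measured compounds named here, no measured pair shows this change on its own, so the expectation rests on that record alone. No step beyond the scatter is expected in this assay, and the estimate reads a step that the limit leaves unreadable from compound 1 to compound 3. For compound 3, the expected value is 30 ug/mL, with an estimated range of 12 ug/mL to 60 ug/mL.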

Compound 3, concentration for half-maximal effect: > 25 ug/mL
Compound 3: only a limit was reported; the forecaster's own chance of this, stated with the estimate: 65%; the middle value is on the limit's open side.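

Compound 3 gives > 25 ug/mL in this assay, which is a limit and not a number. Compound 1 also stands at a limit, so no step from compound 1 to compound 3 can be read: the limit of > 25 ug/mL in this assay, at which 3 of the 3 values shown sit.

The compounds shown leave open whether amino in place of bromo changes the read-out at all.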